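Aryl carbamate series: methoxy for isopropyl on compound 1

A few compounds are considered here, and "the series" means these few. Any claim that something is new, unique, unknown or untested is made for them only; others in the source may bear on it.

Measured so far:
compound 1, `C=C1C(=O)OC[C@@H]1CCOC(=O)Nc1ccc(C(C)C)cc1`: 1580 nM
compound 2, `C=C1C(=O)OC[C@H]1CCOC(=O)Nc1ccc(C(C)C)cc1`: 340 nM

Going by the values given here, in a functional assay on RAW264.7 cells (Mus musculus) for inhibition, with a stated time of 30 min (a lower number here means a stronger inhibitor, a higher number a weaker inhibitor), compound 1 gives 1580 nM, the higher of the two numbers so far, and compound 2 gives 340 nM. Among the compounds with values here, the single measured step, a 4.6-fold lower number from compound 1 to compound 2 (0.67 log units; beyond the scatter), is a change of configuration only the fact that compounds 1 and 2 differ only in the configuration as drawn and leaves the aryl substituent untouched.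

Compound 3, `C=C1C(=O)OC[C@@H]1CCOC(=O)Nc1ccc(OC)cc1`, carries methoxy in place of isopropyl on an aromatic carbon relative to compound 1. Within the data shown here, no measured step bears on this change, so no shift beyond the scatter is expected in either direction, and the range is kept wide. Compound 3 is estimated at 1800 nM, between 500 nM and 6500 nM, meaning an expected step of a 1.1-fold higher number from compound 1 to compound 3 (0.06 log units; within the scatter).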

Compound 3, half-maximal inhibitory concentration: 1090 nM
The estimate for compound 3 lay 1.7-fold (0.22 log units) above the measured number; the range from low to high includes it.
By their numbers in this assay, from the lowest: compound 2; then compounds 3 and 1 (each within the scatter of the next).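

In this assay, the aromatic carbon para to a large group accepts methoxy in place of isopropyl without a change beyond the scatter, with a 1.4-fold lower number from compound 1 to compound 3 (0.16 log units; within the scatter) as the step. This exchange of substituent therefore has a much smaller reach here than the size of the step printed for configuration, a 4.6-fold lower number from compound 1 to compound 2 (0.67 log units; beyond the scatter) as the comparison. Nothing available explains the result for methoxy.

Open, as far as these compounds go, is whether methoxy behaves alike on the configuration of compound 2. Also open, from the compounds shown here alone, is whether an amine, a carboxylic acid or a longer chain at this position moves the number beyond the scatter.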